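A Single Chloro Added to the Benzamide of Compound 2

A few compounds are considered here, and "the series" means these few. Any claim that something is new, unique, unknown or untested is made for them only; others in the source may bear on it.

Compound 1 `Cc1ccc(C(=O)Nc2cccc(Nc3ccc([N+](=O)[O-])c4ncnc(O)c34)c2)cc1`: in an ADME assay on L02 cells (Homo sapiens) for cytotoxicity (a lower number here means a stronger inhibitor, a higher number a weaker inhibitor), compound 1 gives "not determined" (no result reported).
Compound 2 `O=C(Nc1ccc(Nc2ccc([N+](=O)[O-])c3ncnc(O)c23)cc1)c1ccccc1`: in this assay compound 2 gives 65300 nM.

For the measured compounds named here, compound 2 holds the only number in this set. Compound 1 carries no result, so compound 2 stands alone, with nothing measured to be set against it. Compound 3 `O=C(Nc1ccc(Nc2ccc([N+](=O)[O-])c3ncnc(O)c23)cc1)c1ccc(Cl)cc1` differs from compound 2 in one place: chloro in place of hydrogen on an aromatic carbon. Going by the values given here, no pair of measured compounds shows what this change does in this assay, so the step can only be guessed from the size of the change itself, which enters a single heavy atom and no ring. The step from compound 2 to compound 3 is expected to stay within the usual scatter, leaning if anything toward a slightly lower number. Compound 3 is expected to give 50000 nM in this assay, with a range from 20000 nM to 130000 nM. The expected step is a 1.3-fold lower number from compound 2 to compound 3 (0.12 log units; within the scatter).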

Compound 3, half-maximal inhibitory concentration: 73500 nM
Compound 3: the middle estimate sits 1.5-fold (0.17 log units) below what was measured; measured number inside the range.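

In this assay, for the compounds shown here, the change from phenyl to 4-chlorophenyl gives a 1.1-fold higher number from compound 2 to compound 3 (0.05 log units; within the scatter) and so provides the first measured step in this set. On this aromatic carbon, para to a large group, adding one chlorine atom does not separate the two compounds in this assay, although this single pair cannot show whether the same would hold elsewhere in the molecule. Nothing available here offers an explanation for this result.

On these data alone, it remains open whether a different group at this same place, such as an amine, a carboxylic acid or a longer chain, would move the number beyond the usual scatter. As far as these compounds go, it is also open whether chloro on another carbon of the same ring would behave as it does here.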